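Swapping the benzyl ether's substituent on a weak antagonist

The compounds below may be only part of what the source reports. "The series", "measured", "known", "first", "only" and "open" are said of these compounds alone.

Compound 1 `COc1cc(OCc2ccccc2OC)c2cc(-c3cn4nc(OC)sc4n3)oc2c1` is the starting point. In an assay on a cell-free system (plasma) for antagonist activity at proteinase-activated receptor 4 (Homo sapiens), with a stated time of 5 min, in the presence of a further agent that is not named here (a lower number here means a stronger inhibitor, a higher number a weaker inhibitor), compound 1 gives > 1000 nM, which is a limit of the assay rather than a number. Compound 2 `COc1nn2cc(-c3cc4ccc(OCc5ccccc5)cc4o3)nc2s1` gives > 30000 nM in this assay, also a limit. Compound 3 `COc1cc(OCc2ccccc2OCc2ccccc2)c2cc(-c3cn4nc(OC)sc4n3)oc2c1` gives 2500 nM in this assay. The step that the limit leaves unreadable from compound 1 to compound 3 cannot be sized because of the limit of > 1000 nM in this assay, at which 1 of the 3 values shown sits. The new compound 4 `COc1cc(OCc2cccc(O)c2)c2cc(-c3cn4nc(OC)sc4n3)oc2c1` carries the change (3-hydroxyphenyl in place of 2-methoxyphenyl on a saturated chain carbon bound to an oxygen on an aromatic ring). Going by the values given here, no measured step covers this change, and the one measured step is unreadable, so only the limit of compound 1 anchors the expectation. The step that the limit leaves unreadable from compound 1 to compound 4 is therefore expected to be small. Compound 4 is estimated at 3000 nM, within the range 1000 nM to 15000 nM.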

Compound 4, half-maximal inhibitory concentration: 2700 nM
For compound 4 the middle estimate is 1.1-fold (0.05 log units) above the measured one; the measured number falls inside the stated range.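

No step can be read from compound 1 to compound 4, because compound 1 gives only a limit and not a number: the limit of > 1000 nM in this assay, at which 1 of the 4 values shown sits. On these data alone, how far replacing 2-methoxyphenyl with 3-hydroxyphenyl shifts inhibition therefore stays open.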